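The compounds below may be only part of what the source reports. "The series", "measured", "known", "first", "only" and "open" are said of these compounds alone.

Compound 1 `CCN(CC)CN1C(=O)/C(=N\NC(=S)NO)c2cc(Cl)ccc21` and compound 2 `CCN(CC)CN1C(=O)/C(=N\NC(=S)NO)c2cc(F)ccc21` share one core and differ only at a single aromatic carbon. In an ADME assay on MT4 cells (Homo sapiens) for cytotoxicity, read by spectrophotometry, with a stated time of 5 days (on this read-out higher numbers stand for lower toxicity in this test and lower numbers for higher toxicity in this test), compound 1 gives 562000 nM, and in this assay compound 2 gives 521000 nM; the move from compound 2 to compound 1 is chloro in place of fluoro on an aromatic carbon, and it makes a 1.1-fold higher number from compound 2 to compound 1 (0.03 log units; within the scatter). Compound 3 `CONC(=S)N/N=C1\C(=O)N(CN2CCN(c3c(F)cc4c(=O)c(C(=O)O)cn(C5CC5)c4c3OC)CC2C)c2ccc(F)cc21` has a different core; how its core differs from that of compound 2 is not broken down here. In this assay compound 3 gives 171000 nM, the lowest of the three numbers, beyond the scatter from both compound 1 and compound 2.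

Compound 4 `CONC(=S)N/N=C1\C(=O)N(CN2CCN(c3c(F)cc4c(=O)c(C(=O)O)cn(C5CC5)c4c3OC)CC2C)c2ccc(Cl)cc21` is not yet measured. It differs from compound 3 by chloro in place of fluoro on an aromatic carbon, the same change as that from compound 2 to compound 1, made on the same kind of place in both cases. On the earlier core that change left the number within the scatter, so the step from compound 3 to compound 4 is expected to be small as well, about a 1.1-fold higher number from compound 3 to compound 4 (0.03 log units; within the scatter), resting on a 1.1-fold higher number from compound 2 to compound 1 (0.03 log units; within the scatter). Compound 4 is therefore estimated at 185000 nM, most likely between 100000 nM and 350000 nM.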

Compound 4, half-maximal cytotoxic concentration: 164000 nM
Estimate against measurement, compound 4: 1.1-fold (0.05 log units) above; measured number inside the range.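

On the core of compound 3, chloro in place of fluoro on an aromatic carbon makes a 1.0-fold lower number from compound 3 to compound 4 (0.02 log units; within the scatter) in this assay. Set beside the earlier step on the core of compound 2, the two results do not differ: the same change on two cores in this assay, a 1.1-fold higher number (0.03 log units; within the scatter) from compound 2 to compound 1 and a 1.0-fold lower number (0.02 log units; within the scatter) from compound 3 to compound 4, 1.1-fold (0.05 log units) apart, within the scatter of two such steps. Among these compounds, this shows that on these two cores the change behaves alike in this test, with neither step reaching beyond the scatter, but it rests on only two pairs and one kind of place, and it shows only that a step too small to read stayed too small to read, not that a larger step would carry over from one core to another or that other cores would follow.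

The compounds shown leave open whether a bromo, a nitrile or an amine on the same aromatic carbon would also stay within the scatter on both cores. They also leave open whether the same change would hold on a core carrying a longer chain in place of the diethylamino group of compound 1.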